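The source may report more compounds than this note shows. Statements on the series, on what has been measured and on what is new or still open speak of the compounds shown alone.

Measured so far in a functional assay on LoVo cells (Homo sapiens) for inhibition, read by MTT assay, with a stated time of 72 h; a higher number here means a weaker inhibitor, a lower number a stronger inhibitor:

- compound 1 `C=C(Br)C(=O)Nc1cccc(/C=C/C(=O)Nc2ccccc2)c1`: 3900 nM
- compound 2 `C=C(Br)C(=O)Nc1cccc(/C=C/C(=O)Nc2cccc(F)c2)c1`: 1000 nM

Compound 2 holds the lower of the two numbers, which makes it the stronger inhibitor so far. Compound 3 `C=C(Br)C(=O)Nc1cccc(/C=C/C(=O)Nc2ccc(F)c(F)c2)c1` adds one change to it, (fluoro in place of hydrogen on an aromatic carbon), with fluoro in place of hydrogen on an aromatic carbon, turning 3-fluorophenyl to 3,4-difluorophenyl. For the measured compounds named here, only one measured step bears on this, the same kind of replacement, a 3.9-fold lower number from compound 1 to compound 2 (0.59 log units; beyond the scatter). A single step is thin evidence, so a smaller move towards a lower number is expected. Compound 3 is expected at 700 nM, with an estimated range from 250 nM to 2000 nM. That estimate means an expected 1.4-fold lower number from compound 2 to compound 3 (0.15 log units; within the scatter).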

Compound 3, half-maximal inhibitory concentration: 540 nM
Estimate against measurement, compound 3: 1.3-fold (0.11 log units) above; the measured number falls inside the stated range.
By their numbers in this assay, from the lowest: compounds 3 and 2 (each within the scatter of the next); then compound 1.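

A second fluoro, placed ortho to the first and para to a large group, gives a 1.9-fold lower number from compound 2 to compound 3 (0.27 log units; within the scatter), so in this assay this further replacement cannot be separated from the scatter. Measured from the unsubstituted phenyl, the 3,4-difluorophenyl group gives a 7.2-fold lower number from compound 1 to compound 3 (0.86 log units; beyond the scatter), which is a clear step. No available measurement explains these numbers. Still open, going by these compounds, is how a chloro, a methoxy or an amine at this same place would read in this assay, and whether a 4-fluorophenyl group alone would match the 3,4-difluorophenyl group.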